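A few compounds are considered here, and "the series" means these few. Any claim that something is new, unique, unknown or untested is made for them only; others in the source may bear on it.

In a functional assay on HCT-116 cells (Homo sapiens) for antiproliferative activity, read by MTT assay, with a stated time of 72 h (on this read-out lower numbers stand for stronger inhibition and higher numbers for weaker inhibition), compound 1 `COc1c(NS(=O)(=O)c2ccc(F)cc2)cc(-c2ccc3nc(NC(C)=O)sc3c2)cc1C(N)=O` gives 1950 nM, the lowest of the three numbers recorded. Compound 2 `COc1c(NS(=O)(=O)c2ccc(F)cc2)cc(-c2ccc3nc(NC(=O)C4CC4)sc3n2)cc1C(N)=O` gives 2500 nM, which lies within the scatter of compound 1, so no order between the two can be read. Compound 3 `COc1c(NS(=O)(=O)c2ccc(Cl)cc2)cc(-c2ccc3nc(NC(C)=O)nn3c2)cc1C(N)=O` gives 31700 nM, beyond the scatter and clearly weaker. Compound 4 `COc1c(NS(=O)(=O)c2ccc(F)cc2)cc(-c2ccc3nc(NC(=O)C4CC4)sc3c2)cc1C(N)=O` has not been measured; it differs from compound 1 by cyclopropyl in place of methyl on a carbonyl carbon. Within the data shown here, no single-point step between measured compounds covers this change, and compound 2, which carries the cyclopropylcarbonyl group on a different core, cannot be set against compound 1 as such a step. The expected step is a 1.0-fold higher number from compound 1 to compound 4 (0.01 log units; within the scatter), none beyond the scatter. Compound 4 is estimated at 2000 nM, with a range from 1000 nM to 4000 nM.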

Compound 4, half-maximal inhibitory concentration: 2010 nM
The estimate for compound 4 lay 1.0-fold (0.00 log units) below the measured number, and the stated range covers the measured number.
By their numbers in this assay, from the lowest: compounds 1, 4 and 2 (each within the scatter of the next); then compound 3.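

In this assay, among these compounds, cyclopropyl in place of methyl on a carbonyl carbon gives a 1.0-fold higher number from compound 1 to compound 4 (0.01 log units; within the scatter) on the shared core, the only single-change reading at this place. The acetamido position therefore takes (cyclopropylcarbonyl)amino, with its added three-membered carbon ring, without a readable change in the number. No measured property bears on this result.

From the compounds shown here alone, whether a longer chain, an amine or a carboxylic acid on this carbonyl carbon would also stay within the scatter remains open. Compound 3 differs from compound 1 in more than one place, so what lies behind its number also remains open.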